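The compounds below may be only part of what the source reports. "The series", "measured", "known", "first", "only" and "open" are said of these compounds alone.

Compound 2 `CC(C)N1C(=O)C(Cc2ccc(Cl)cc2)COC12C=CC(=O)C=C2` stands at the limit of an assay on isolated protein for inhibition of N-lysine methyltransferase SMYD2 (Homo sapiens), read by filter binding, with a stated time of 1 h; a higher number here means a weaker inhibitor, a lower number a stronger inhibitor: it gives > 20000 nM, which is a limit of the assay and not a number. Compound 3 `CC(C)N1C(=O)C(Cc2ccc(F)cc2)COC12C=CC(=O)C=C2` likewise gives only a limit in this assay, > 20000 nM. Compound 1 `O=C1C=CC2(C=C1)OCC(Cc1cc(C(F)(F)F)cc(C(F)(F)F)c1)C(=O)N2c1ccccc1` gives 18500 nM in this assay. Compound 4 `CC(C)N1C(=O)C(Cc2ccc([N+](=O)[O-])cc2)COC12C=CC(=O)C=C2` differs from compound 2 by nitro in place of chloro on an aromatic carbon, a nitro in place of chloro on an aromatic carbon. For the measured compounds named here, the only measured step that swaps a group on such an aromatic carbon, a step that the two limits leave unreadable from compound 2 to compound 3, cannot be read because both of its ends sit at the limit of > 20000 nM in this assay, at which 2 of the 3 values shown sit. Going by the values given here, no measured step therefore tells the size of the new change, so the estimated step that the limit leaves unreadable from compound 2 to compound 4 is kept small. Compound 4 is expected to give 25000 nM, between 10000 nM and 60000 nM.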

Compound 4, half-maximal inhibitory concentration: > 20000 nM
Compound 4 ended at the assay's limit; the forecaster's own chance of this, stated with the estimate: 70%; the middle value lies beyond the limit too.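

For the compounds shown here, no step among compound 2, compound 3 and compound 4 can be read, since each gives only a limit of the assay and not a number: the limit of > 20000 nM in this assay, at which 3 of the 4 values shown sit.
On these data alone, whether chloro, fluoro or nitro on the aromatic carbon changes the result in this assay stays open.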